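The source may report more compounds than this note shows. Statements on the series, on what has been measured and on what is new or still open speak of the compounds shown alone.

The measured compounds and their values:

Compound 1, `N#Cc1c(N)nc(SCC(=O)NCO)c(C#N)c1-c1ccc(OCC2CC2)cc1` — 10%
Compound 2, `N#Cc1c(N)nc(SCc2nnn[nH]2)c(C#N)c1-c1ccc(OCC2CC2)cc1` — 3%
Compound 3, `N#Cc1c(N)nc(SCc2nc3ccccc3[nH]2)c(C#N)c1-c1ccc(OCC2CC2)cc1` — 21%

In an assay on CHO cells for displacement of a labelled ligand from adenosine receptor A1 (Homo sapiens), read by scintillation counting, with a stated time of 90 min, tested at 1 uM (on this read-out lower numbers stand for less inhibition and higher numbers for more inhibition at the one concentration tested (going by the name of the read-out)), compound 3 gives 21%, the highest of the three numbers. Its nearest neighbour is compound 1, with 10%; the furthest is compound 2, with 3%. The step of a number 11 percentage points higher from compound 1 to compound 3 (beyond the scatter) and the step of a number 18 percentage points higher from compound 2 to compound 3 (beyond the scatter) both show the 1H-benzimidazol-2-yl group on the saturated chain carbon bound to a sulfur giving a modest gain over the two smaller groups, while a number 7 percentage points lower from compound 1 to compound 2 (within the scatter) shows the two smaller groups lying close together.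

Compound 4, `N#Cc1c(N)nc(SCc2cnc[nH]2)c(C#N)c1-c1ccc(OCC2CC2)cc1`, differs from compound 3 in one place: 1H-imidazol-5-yl in place of 1H-benzimidazol-2-yl on a saturated chain carbon bound to a sulfur

The change removes the six-membered aromatic ring of carbon only and keeps a five-membered aromatic ring with 2 hetero atoms, so it moves back toward the kind of group seen in compound 2. The two steps that bear on it, a number 18 percentage points higher from compound 2 to compound 3 (beyond the scatter) and a number 11 percentage points higher from compound 1 to compound 3 (beyond the scatter), both rose on going to the 1H-benzimidazol-2-yl group, so the reverse direction is expected here: a modest fall in this assay from compound 3 to compound 4, a number 13 percentage points lower from compound 3 to compound 4 (beyond the scatter), is estimated. Compound 4 is therefore expected to give about 8% in this assay, within a range from 0% to 22%.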

Compound 4, a percentage reported as inhibition, at one concentration (the size of the read-out at that concentration, not a potency): 1%
Estimate against measurement, compound 4: 7 percentage points above; the measured number falls inside the stated range.
By their numbers in this assay, from the lowest: compounds 4, 2 and 1 (each within the scatter of the next); then compound 3.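

In this assay, the change from 1H-benzimidazol-2-yl to 1H-imidazol-5-yl on a saturated chain carbon bound to a sulfur gives a number 20 percentage points lower from compound 3 to compound 4 (beyond the scatter) and takes away the six-membered aromatic ring of carbon only, while the five-membered aromatic ring with 2 hetero atoms and the counts of 1 hydrogen-bond donor and 1 hydrogen-bond acceptor stay the same; among these two compounds, the higher number therefore goes with the complete 1H-benzimidazol-2-yl group and is not kept by the five-membered ring alone. The other two comparisons, a number 2 percentage points lower from compound 2 to compound 4 (within the scatter) and a number 9 percentage points lower from compound 1 to compound 4 (within the scatter), place compound 4 with compound 1 and compound 2 despite their three different groups, so that only compound 3 stands apart among the four compounds. Nothing given here accounts for this result.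

Going by these compounds, whether a phenyl group on the same chain carbon, with no five-membered ring, would match compound 3 remains open, as does the effect of a methyl or chloro group on the 1H-benzimidazol-2-yl group. Also open, on these data alone, is what a longer chain between the sulfur and the 1H-benzimidazol-2-yl group, or a carboxylic acid or an amine at this place, would give.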